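A few compounds are considered here, and "the series" means these few. Any claim that something is new, unique, unknown or untested is made for them only; others in the source may bear on it.

Of the compounds shown here, three built on one shared core have been measured in a functional assay on the whole organism (strain Wistar) for inhibition, with Rattus norvegicus as the target, read by paw edema, with stated times of 30 min and 3 h, at a dose of 100 mg/kg by the oral route; on this read-out higher numbers stand for more inhibition at the one dose given (going by the name of the read-out) and lower numbers for less inhibition. Compound 1 `COc1cc(C(=O)N2CCCC2)nn1-c1ccccc1` gives 29.2% in this assay. Compound 2 `COc1cc(C(=O)N2CCCCC2)nn1-c1ccccc1` differs from compound 1 by piperidin-1-yl in place of pyrrolidin-1-yl on a carbonyl carbon, and in this assay compound 2 gives 28.2%; the step of a number 1 percentage points lower from compound 1 to compound 2 (within the scatter) is within the scatter, so the two values show nothing that can be told apart. Compound 3 `CCCCOc1cc(C(=O)N2CCCC2)nn1-c1ccccc1` differs from compound 1 by propyl in place of hydrogen on a saturated chain carbon bound to an oxygen on an aromatic ring, which is also how the core of compound 3 differs from the core of compound 1. In this assay compound 3 gives 17.6%, the lowest of the three numbers, and the step of a number 11.6 percentage points lower from compound 1 to compound 3 (beyond the scatter) lies beyond the scatter.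

Compound 4 `CCCCOc1cc(C(=O)N2CCCCC2)nn1-c1ccccc1` has not yet been measured in this assay. It differs from compound 3 by piperidin-1-yl in place of pyrrolidin-1-yl on a carbonyl carbon. This is the same change that leads from compound 1 to compound 2, made at the same place, and it occurs twice among these four compounds; where it was measured it made the step of a number 1 percentage points lower from compound 1 to compound 2 (within the scatter). Compound 4 is therefore expected to stay close to compound 3, with an expected step of a number 1.1 percentage points lower from compound 3 to compound 4 (within the scatter), because the step of a number 1 percentage points lower from compound 1 to compound 2 (within the scatter) from the same change on the core of compound 1 stayed within the scatter. Compound 4 is estimated at 16.5% in this assay, with a likely range from 6% to 27%.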

Compound 4, a percentage reported as inhibition, in the whole organism at one dose (the size of the read-out at that dose, not a potency): 15.6%
Compound 4: middle estimate off by 0.9 percentage points, on the high side; the measured number falls inside the stated range.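

In this assay, piperidin-1-yl in place of pyrrolidin-1-yl on a carbonyl carbon gave a number 2 percentage points lower from compound 3 to compound 4 (within the scatter), and this agrees with the same change on the core of compound 1: the same change on two cores in this assay, a number 1 percentage points lower (within the scatter) from compound 1 to compound 2 and a number 2 percentage points lower (within the scatter) from compound 3 to compound 4, 1 percentage points apart, within the scatter of two such steps. Propyl in place of hydrogen on a saturated chain carbon bound to an oxygen on an aromatic ring gave a number 12.6 percentage points lower from compound 2 to compound 4 (beyond the scatter), so this change also carried over between the pyrrolidin-1-yl and piperidin-1-yl amides: the same change on two cores in this assay, a number 11.6 percentage points lower (beyond the scatter) from compound 1 to compound 3 and a number 12.6 percentage points lower (beyond the scatter) from compound 2 to compound 4, 1 percentage points apart, within the scatter of two such steps. Within these four compounds, each change therefore behaved the same way on both cores, but this does not show that it would do so on any other core, and neither step between the two amide rings separates the pyrrolidin-1-yl compound from its piperidin-1-yl partner.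

The compounds shown leave open how a morpholine or an open-chain amine such as diethylamine would read on the carbonyl carbon, and whether the two changes would still combine in the same way there. They also leave open how an ethyl chain or a longer chain such as hexyl on the oxygen would compare with the methyl and butyl chains seen here.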